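Changing the Aryl Group from Compound 3 to Compound 4

The source may report more compounds than this note shows. Statements on the series, on what has been measured and on what is new or still open speak of the compounds shown alone.

Measured so far:
compound 1, `COc1ccc(-c2cc(Cl)cc(C(=O)Nc3nn[nH]n3)n2)cc1`: 100%
compound 2, `Nc1ccc(-c2cc(Cl)cc(C(=O)Nc3nn[nH]n3)n2)cc1`: 100%
compound 3, `COc1cc(C(=O)Nc2nn[nH]n2)nc(-c2ccccc2OC)c1`: 68%

In a functional assay on the whole organism with Rattus norvegicus as the target, at a dose of 3 mg/kg by the oral route (a lower number here means a weaker effect, a higher number a stronger effect of the compound at the dose given), compound 1 gives 100% and compound 2 gives 100%, whereas compound 3 gives 68%, the lowest of the three and beyond the scatter below both others. Compound 4, `CNc1ccc(-c2cc(OC)cc(C(=O)Nc3nn[nH]n3)n2)cc1`, is not yet measured; it differs from compound 3 by 4-(methylamino)phenyl in place of 2-methoxyphenyl on an aromatic carbon. Among the measured compounds shown here, the one measured step, no change at the digits printed from compound 1 to compound 2 (within the scatter), shows that an amino in place of a methoxy on the phenyl ring left the read-out unchanged, so the methylamino group itself gives no reason to expect a shift. Compound 4 carries its phenyl substituent as compounds 1 and 2 do, but keeps the methoxy of compound 3 on the shared core. The step of a number 17 percentage points higher from compound 3 to compound 4 (beyond the scatter) is expected to be upward, though uncertain. Compound 4 is therefore expected to give 85%, within 55% to 100%.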

Compound 4, a percentage reported as inhibition, in the whole organism at one dose (the size of the read-out at that dose, not a potency): 79%
Beside the measured number, compound 4's estimate is 6 percentage points above it, and the stated range covers the measured number.
By their numbers in this assay, from the lowest: compound 3; then compound 4; then compounds 1 and 2 (each within the scatter of the next).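

At this position, next to the ring nitrogen, the read-out in this assay shows a number 11 percentage points higher from compound 3 to compound 4 (beyond the scatter) when 4-(methylamino)phenyl enters and 2-methoxyphenyl leaves, so the aryl group here does affect the result at this dose. The change swaps both the substituent and its place on the phenyl ring, so this single step cannot separate the two. Nothing available explains the step. Going by these compounds, it remains open whether the substituent matters at all, which an unsubstituted phenyl would test, and whether 4-(dimethylamino)phenyl, which lacks the amine hydrogen, would behave like 4-(methylamino)phenyl.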